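Urea series with chloropyrazine arm: methyl-to-hydrogen step

The source may hold more compounds than are shown below. What is called first, only, known or untested is meant among the compounds shown, and "the series" means these compounds.

Measured compounds:
Compound 1, `CCOc1ccc(NC(=O)Nc2cccc(CNc3nccnc3Cl)c2)cc1`, 7050 nM in a functional assay on HepG2 cells (Homo sapiens) for antiproliferative activity, read by MTT assay, with a stated time of 48 h; on this read-out higher numbers stand for weaker inhibition and lower numbers for stronger inhibition.
Compound 2, `COc1ccc(NC(=O)Nc2cccc(CNc3nccnc3Cl)c2)cc1`, 12000 nM.
Compound 3, `CCc1ccccc1NC(=O)Nc1cccc(CNc2nccnc2Cl)c1`, 7860 nM.

All three share one core and differ only in the aryl group on the urea nitrogen. The step of a 1.7-fold higher number from compound 1 to compound 2 (0.23 log units; within the scatter) is described as hydrogen in place of methyl on a saturated chain carbon bound to an oxygen on an aromatic ring. The step of a 1.1-fold higher number from compound 1 to compound 3 (0.05 log units; within the scatter) rests on the difference (2-ethylphenyl in place of 4-ethoxyphenyl on an amide-type nitrogen). Between compound 2 and compound 3 the step is a 1.5-fold lower number from compound 2 to compound 3 (0.18 log units; within the scatter).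

Compound 4, `Cc1ccccc1NC(=O)Nc1cccc(CNc2nccnc2Cl)c1`, has not yet been measured in this assay. It differs from compound 3 by hydrogen in place of methyl on a saturated chain carbon bound to an aromatic carbon. Within the data shown here, this is the same kind of change as the one from compound 1 to compound 2, not the same: there the place was on a saturated chain carbon bound to an oxygen on an aromatic ring, here it is on a saturated chain carbon bound to an aromatic carbon. The two cores differ by 2-ethylphenyl in place of 4-ethoxyphenyl on an amide-type nitrogen.

For compound 4 the expected step is a 1.4-fold higher number from compound 3 to compound 4 (0.15 log units; within the scatter), resting on the earlier step of a 1.7-fold higher number from compound 1 to compound 2 (0.23 log units; within the scatter), which stayed within the scatter. Compound 4 is therefore estimated at 11000 nM, with an expected range from 5000 nM to 25000 nM.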

Compound 4, half-maximal inhibitory concentration: 15300 nM
Compound 4: middle estimate off by 1.4-fold (0.14 log units), on the low side; low and high end bracket the measured number.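

In this assay hydrogen in place of methyl on a saturated chain carbon bound to an aromatic carbon gives a 1.9-fold higher number from compound 3 to compound 4 (0.29 log units; within the scatter) and the same kind of change on the core of compound 1 agrees with it: the same change on two cores in this assay, a 1.7-fold higher number (0.23 log units; within the scatter) from compound 1 to compound 2 and a 1.9-fold higher number (0.29 log units; within the scatter) from compound 3 to compound 4, 1.1-fold (0.06 log units) apart, within the scatter of two such steps. This shows that the step carried over between these two cores, but each step lies within the scatter on its own, and two pairs cannot establish a rule for the series, particularly as the place differs, with one change on a chain carbon bound to an oxygen on an aromatic ring and the other on a chain carbon bound to an aromatic carbon. Of the two steps that exchange the whole aryl group, a 1.3-fold higher number from compound 2 to compound 4 (0.11 log units; within the scatter) stays within the scatter and a 2.2-fold higher number from compound 1 to compound 4 (0.34 log units; beyond the scatter) goes modestly beyond it; neither tests the methyl change.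

The compounds shown leave open how a longer chain such as propyl would behave in this assay. They also leave open what an amine or a carboxylic acid on the aryl ring would do.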